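This account rests on a few compounds, and the source may have more. Where it says the series, first, only, none or still open, it means among the compounds named here.

Measured in a functional assay on FM3A cells (Mus musculus) for inhibition, read by cell counting, with a stated time of 2 days; on this read-out lower numbers stand for stronger inhibition and higher numbers for weaker inhibition:
- compound 1 `CCOc1ccc(-c2nn3cc(-c4cccc(N)c4)nc3s2)cc1`: compound 1 gives >= 250000 nM, which is a limit of the assay and not a number.
- compound 2 `C=C(Br)C(=O)Nc1cccc(-c2cn3nc(-c4ccc(OCC)cc4)sc3n2)c1`: compound 2 gives 1100 nM.
- compound 3 `C=C(Br)C(=O)Nc1cccc(-c2cn3nc(-c4ccc(OC)cc4)sc3n2)c1`: compound 3 gives 890 nM.

Compound 1 stands only at a limit in this assay; it sits at the limit of >= 250000 nM in this assay, at which 1 of the 3 values shown sits, so no number is known for it, only that the read-out did not fall under that limit.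

The step to compound 4 `Nc1cccc(-c2cn3nc(-c4ccc(Cl)cc4)sc3n2)c1` is chloro in place of ethoxy on an aromatic carbon. The amine on the other aromatic ring stays free, as in compound 1.

Two measured steps exist. The step of an at least 220-fold lower number from compound 1 to compound 2 (2.35 log units; beyond the scatter) shows that acylating the aromatic amine is what moves the number from the limit into the measurable range. The step of a 1.2-fold lower number from compound 2 to compound 3 (0.09 log units; within the scatter) shows that shortening the alkoxy group on the para-substituted ring, with the acyl group kept, changes nothing beyond the scatter. Neither step tests chloro in place of ethoxy, and neither tests a change on that ring while the amine is free. Compound 4 keeps the free amine of compound 1, so no step beyond the scatter is expected in this assay: a number no higher from compound 1 to compound 4 (the limit leaves the size open).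

Compound 4 is therefore expected at 250000 nM, in the range 80000 nM to 500000 nM, most likely reported again only as a limit.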

Compound 4, half-maximal inhibitory concentration: 160000 nM
Compound 4: the middle estimate sits 1.6-fold (0.19 log units) above what was measured, and the stated range covers the measured number.
By their numbers in this assay, from the lowest: compounds 3 and 2 (each within the scatter of the next); then compound 4. At a limit, above all of these: compound 1.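

In this assay, compound 4 is the only compound shown with a group other than an alkoxy group on this aromatic carbon, para to a large group, and with the amine on the other aromatic ring still free it gives a real number, 160000 nM. The step is an at least 1.5-fold lower number from compound 1 to compound 4 (0.19 log units; that floor lies within the scatter), so chloro in place of ethoxy, with one heavy atom entering where three leave, is known here only through a floor, and that floor alone does not separate the two compounds. The true size of the step stays open because compound 1 stands at a limit of the assay and not at a number: the limit of >= 250000 nM in this assay, at which 1 of the 4 values shown sits.

Still open, from the compounds shown here alone, is how chloro reads out once the amine carries the (1-bromoethenyl)carbonyl group, a pairing that would place it one change away from compound 2 and allow a direct comparison with the ethoxy group. Also open, going by these compounds, is how other groups on this carbon behave with the amine free or acylated, such as a carboxylic acid, an amine or a longer alkoxy chain.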